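Fluoro for methyl across the ketone and alcohol pairs

The compounds below may be only part of what the source reports. "The series", "measured", "known", "first", "only" and "open" are said of these compounds alone.

Measured compounds, with their largest response reached in an assay on isolated protein with retinoic acid receptor beta (Homo sapiens) as the target; on this read-out higher numbers stand for larger maximal responses and lower numbers for smaller maximal responses:
compound 1 `Cc1cc2c(cc1C(=O)c1ccc3cc(C(=O)O)ccc3c1)C(C)(C)CCC2(C)C` gives 81%
compound 2 `CC1(C)CCC(C)(C)c2cc(C(=O)c3ccc4cc(C(=O)O)ccc4c3)c(F)cc21` gives 81%
compound 3 `Cc1cc2c(cc1C(O)c1ccc3cc(C(=O)O)ccc3c1)C(C)(C)CCC2(C)C` gives 96%

Compound 1 and compound 2 differ in one place: fluoro in place of methyl on an aromatic carbon. On that change the read-out in this assay moves no change at the digits printed from compound 1 to compound 2 (within the scatter), so the fluoro and the methyl compound stand at the same level within the scatter.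

Compound 3 carries a carbinol where compound 1 carries a ketone; the difference between the two cores is not broken down here. Compound 3 gives the highest number of the three, and its gaps to compound 1 and to compound 2 lie beyond the scatter.

Compound 4 `CC1(C)CCC(C)(C)c2cc(C(O)c3ccc4cc(C(=O)O)ccc4c3)c(F)cc21` is not yet measured in this assay. It stands to compound 3 as compound 2 stands to compound 1: fluoro in place of methyl on an aromatic carbon. The place of the change is described in the same words for both pairs, so this is the same change, now made on the carbinol core instead of the ketone core.

Within the data shown here, the expectation for the step from compound 3 to compound 4 in this assay is a number 1 percentage points lower from compound 3 to compound 4 (within the scatter), about the size of no change at the digits printed from compound 1 to compound 2 (within the scatter), because no change at the digits printed from compound 1 to compound 2 (within the scatter) is the only measured instance of this change. The estimate for compound 4 in this assay is therefore 95%, with a range from 83% to 106%.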

Compound 4, largest response reached (reported as maximum), in percent of the reference or control that the assay uses: 30%
Estimate against measurement, compound 4: 65 percentage points above; the whole stated range lies above it.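

In this assay, fluoro in place of methyl on an aromatic carbon gives a number 66 percentage points lower from compound 3 to compound 4 (beyond the scatter), so on the carbinol core of compound 3 this change costs a large part of the maximal response. The change therefore does not carry over with the same size from the ketone core of compound 1 to the carbinol core of compound 3, and in this series the result on one core gives no safe forecast for the other: the same change on two cores in this assay, no change at the digits printed (within the scatter) from compound 1 to compound 2 and a number 66 percentage points lower (beyond the scatter) from compound 3 to compound 4, 66 percentage points apart, beyond the scatter of two such steps This rests on a single pair for each core in a single read-out, so it shows that the outcome of the change depends on the core, but it does not show what in the carbinol core produces the difference, nor whether the same holds for any other target or on any further core.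

As far as these compounds go, whether the loss on the carbinol core is specific to fluoro remains open, and a chloro or an ethyl group on the same aromatic carbon would speak to that. Also open, from the compounds shown here alone, is how far the difference between the cores depends on the hydroxyl group of the carbinol, which a methyl ether or an amine in its place would test.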